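Succinate anilides on a nitrobenzofurazan thioether chain: cytotoxicity notes

The source may report more compounds than this note shows. Statements on the series, on what has been measured and on what is new or still open speak of the compounds shown alone.

Three compounds carry numbers in an ADME assay on HUVEC cells (Homo sapiens) for cytotoxicity, read by MTT assay, with a stated time of 72 h; on this read-out higher numbers stand for weaker inhibition and lower numbers for stronger inhibition:
compound 1 `O=C(O)CCC(=O)OCCCCCCSc1ccc([N+](=O)[O-])c2nonc12` gives 740 nM
compound 2 `COc1ccccc1NC(=O)CCC(=O)OCCCCCCSc1ccc([N+](=O)[O-])c2nonc12` gives 1610 nM
compound 3 `COc1ccc(NC(=O)CCC(=O)OCCCCCCSc2ccc([N+](=O)[O-])c3nonc23)cc1` gives 1590 nM

Compound 2 holds the highest of the three numbers in this assay, though its gap to compound 3 lies within the scatter; only compound 1 sits apart from it, as the step of a 2.2-fold higher number from compound 1 to compound 2 (0.34 log units; beyond the scatter) shows. Within the data shown here, the step of a 2.1-fold higher number from compound 1 to compound 3 (0.33 log units; beyond the scatter) is of the same size, so converting the free acid into either anilide moves the read-out by a modest amount, in the same direction, regardless of where the single methoxy group stands.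

Compound 4 `COc1ccc(NC(=O)CCC(=O)OCCCCCCSc2ccc([N+](=O)[O-])c3nonc23)cc1OC` is not yet measured. Its change from compound 2 is 3,4-dimethoxyphenyl in place of 2-methoxyphenyl on an amide-type nitrogen. The step that bears on it most directly is a 1.0-fold lower number from compound 2 to compound 3 (0.01 log units; within the scatter), in which moving the methoxy group around the ring left the number unchanged. Among the measured compounds shown here, no measured step tests adding a second methoxy group, so the expectation rests on that null step alone. In this assay compound 4 is therefore expected to give a number near that of compound 2, 1600 nM, within 900 nM to 2900 nM. The expected step is a 1.0-fold lower number from compound 2 to compound 4 (0.00 log units; within the scatter), which is not beyond the scatter.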

Compound 4, half-maximal inhibitory concentration: 870 nM
Compound 4: the middle estimate sits 1.8-fold (0.26 log units) above what was measured; measured number outside the range, below it.
By their numbers in this assay, from the lowest: compounds 1, 4, 3 and 2 (each within the scatter of the next, the first and the last beyond it).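

In this assay, the second methoxy group gets its first direct test: a 1.8-fold lower number from compound 3 to compound 4 (0.26 log units; within the scatter) and a 1.9-fold lower number from compound 2 to compound 4 (0.27 log units; within the scatter) both lie within the scatter, so compound 4 cannot be separated from either single-methoxy anilide. The link to the free acid does change, since a 1.2-fold higher number from compound 1 to compound 4 (0.07 log units; within the scatter) also lies within the scatter, whereas compound 2 and compound 3 each stand beyond the scatter from compound 1, so the step from hydroxy to an anilide is not beyond the scatter for every methoxy pattern on the ring. Among these compounds, the four compounds therefore form a chain of overlapping numbers in which only the steps from compound 1 to compound 2 and to compound 3 are resolved, and nothing at hand offers an explanation for this.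

Going by these compounds, it remains open whether a different group on the anilide ring, such as a dimethylamino or a carboxylic acid group, would give a step beyond the scatter from compound 4. A longer chain in place of the present linker is equally untested in the compounds shown, so its effect on the number in this assay is unknown.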